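From pyrrolidine to thiomorpholine at the thiocarbonyl carbon

A few compounds are considered here, and "the series" means these few. Any claim that something is new, unique, unknown or untested is made for them only; others in the source may bear on it.

Compound 2 `Cc1cccc(/C(N)=N/NC(=S)N2CCCC2)n1` gives 56.8% in a functional assay on HeLa cells (Homo sapiens) for cytotoxicity, read by MTT assay, with a stated time of 72 h, tested at 3 uM (on this read-out lower numbers stand for less inhibition of growth and higher numbers for more inhibition of growth at the one concentration tested), the highest of the three numbers measured. Compound 1 `Cc1ccnc(/C(N)=N/NC(=S)N2CCSCC2)c1` gives 40.4%, and compound 3 `N/C(=N\NC(=S)N1CCCC1)c1ccccn1` gives 38.5%. For the measured compounds named here, the only single-point step measured, a number 18.3 percentage points lower from compound 2 to compound 3 (beyond the scatter), concerns hydrogen in place of methyl on an aromatic carbon and leaves the ring on the thiocarbonyl carbon untouched. Compound 4 `Cc1cccc(/C(N)=N/NC(=S)N2CCSCC2)n1` differs from compound 2 by thiomorpholin-4-yl in place of pyrrolidin-1-yl on a thiocarbonyl carbon. Going by the values given here, compound 1 and compound 3 each carry one of these two rings but differ in two places, so their values show only that each lies below compound 2. Among the compounds with values here, with no step bearing directly on the ring exchange, no change beyond the scatter is expected, and the estimated step is a number 6.8 percentage points lower from compound 2 to compound 4 (within the scatter). Compound 4 is therefore estimated at 50%, within a range from 35% to 65%.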

Compound 4, percent growth inhibition at one concentration: 54.6%
Compound 4: the middle estimate sits 4.6 percentage points below what was measured; the range from low to high includes it.
By their numbers in this assay, from the lowest: compounds 3 and 1 (each within the scatter of the next); then compounds 4 and 2 (each within the scatter of the next).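

In this assay, for the compounds shown here, the exchange of pyrrolidin-1-yl for thiomorpholin-4-yl on a thiocarbonyl carbon gives a number 2.2 percentage points lower from compound 2 to compound 4 (within the scatter), the only step that reads this position directly. On the core of compound 2, either ring therefore serves at this one concentration, whereas the earlier single step concerned only the aromatic methyl. No evidence accounts for this result.

From the compounds shown here alone, whether piperidin-1-yl, morpholin-4-yl or an open-chain dimethylamino group would read the same at this carbon remains open. So does whether the ring exchange holds on the core of compound 3.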